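This account rests on a few compounds, and the source may have more. Where it says the series, first, only, none or still open, it means among the compounds named here.

Measured so far:
compound 1, `COc1ccc(C(=O)Nc2cccc(-c3oc4cc(-c5ccc(F)cc5)ccc4c(=O)c3O)c2)cc1`: 16500 nM
compound 2, `O=C(Nc1cccc(-c2oc3cc(-c4ccc(F)cc4)ccc3c(=O)c2O)c1)c1ccc(F)cc1F`: 11200 nM
compound 3, `COc1ccccc1C(=O)Nc1cccc(-c2oc3cc(-c4ccc(F)cc4)ccc3c(=O)c2O)c1`: 5110 nM

All three values come from a functional assay on MDA-MB-231 cells (Homo sapiens) for antiproliferative activity, read by CCK-8 assay, with a stated time of 72 h; a higher number here means a weaker inhibitor, a lower number a stronger inhibitor. Compound 3 stands lowest of the three, since the steps of a 3.2-fold lower number from compound 1 to compound 3 (0.51 log units; beyond the scatter) and a 2.2-fold lower number from compound 2 to compound 3 (0.34 log units; beyond the scatter) both lie beyond the scatter. Compound 4, `O=C(Nc1cccc(-c2oc3cc(-c4ccc(F)cc4)ccc3c(=O)c2O)c1)c1ccc(C(F)(F)F)cc1`, differs from compound 3 in one place: 4-(trifluoromethyl)phenyl in place of 2-methoxyphenyl on a carbonyl carbon. Both measured steps bear on this. Each of them replaced a differently named phenyl group with 2-methoxyphenyl and gave a modestly lower number; compound 4 moves the other way, from 2-methoxyphenyl to a group named with a substituent in the 4-position, as in compound 1. A modest rise is therefore expected. Compound 4 is estimated at 12000 nM, with a range of 4000 nM to 35000 nM. For compound 4 this amounts to an expected step of a 2.3-fold higher number from compound 3 to compound 4 (0.37 log units; beyond the scatter).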

Compound 4, half-maximal inhibitory concentration: 29400 nM
Beside the measured number, compound 4's estimate is 2.5-fold (0.39 log units) below it; measured number inside the range.
By their numbers in this assay, from the lowest: compound 3; then compounds 2, 1 and 4 (each within the scatter of the next, the first and the last beyond it).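

At this carbonyl carbon, 4-(trifluoromethyl)phenyl in place of 2-methoxyphenyl gives a 5.8-fold higher number from compound 3 to compound 4 (0.76 log units; beyond the scatter) and is the largest step among these compounds. In place of 2,4-difluorophenyl it gives a 2.6-fold higher number from compound 2 to compound 4 (0.42 log units; beyond the scatter) and thus also stands apart from that group. Trifluoromethyl in place of methoxy gives a 1.8-fold higher number from compound 1 to compound 4 (0.25 log units; within the scatter) and so does not separate those two compounds.

As far as these compounds go, what an amine or a carboxylic acid would do at this carbonyl carbon, in place of the phenyl groups, stays open. No evidence here explains why these groups differ.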